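This account rests on a few compounds, and the source may have more. Where it says the series, first, only, none or still open, it means among the compounds named here.

Compound 2 `Cc1cc(C)c(NC(=O)N(Cc2cccc(-n3cccc3)c2)C2CCCCCC2)c(C)c1` is followed here in a functional assay on a cell-free system (plasma) with sterol O-acyltransferase, Soat (Rattus norvegicus) as the target (on this read-out lower numbers stand for an effect already at smaller amounts and higher numbers for an effect only at larger amounts of compound), where compound 2 gives 0.17 mg/kg. Among the two numbers shown it is the lowest; compound 3 `Cc1cc(C)c(NC(=O)N(Cc2ccc(-c3cccnc3)cc2)C2CCCCCC2)c(C)c1` gives 0.58 mg/kg in this assay, a difference beyond the usual scatter. Compound 1 `CSc1cc(C)nc(SC)c1NC(=O)N(Cc1ccccc1)Cc1ccc(-c2cc[nH]n2)cc1` is reported only as a limit, < 0.32 mg/kg in this assay (the limit of < 0.32 mg/kg in this assay, at which 1 of the 3 values shown sits). Compound 4 `Cc1cc(C)c(NC(=O)N(Cc2cccc(-c3cnn(C)c3)c2)C2CCCCCC2)c(C)c1` differs from compound 2 in one place: 1-methyl-1H-pyrazol-4-yl in place of 1H-pyrrol-1-yl on an aromatic carbon. Among the compounds with values here, no measured pair shows a change of this kind, so the outcome in this assay is open; the step from compound 2 to compound 4 is expected to be small, a 1.8-fold higher number from compound 2 to compound 4 (0.25 log units; within the scatter), and not clearly beyond the scatter. Compound 4 is therefore estimated at 0.3 mg/kg in this assay, within a range from 0.1 mg/kg to 1 mg/kg.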

Compound 4, dose for half-maximal effect: < 1 mg/kg
Compound 4 ended at the assay's limit (the forecaster's own chance of this, stated with the estimate: 10%); the middle value is on the limit's open side.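

Compound 4 is reported only as a limit of < 1 mg/kg in this assay and so the step from compound 2 to compound 4 cannot be read. Whether 1-methyl-1H-pyrazol-4-yl in place of 1H-pyrrol-1-yl on an aromatic carbon gives a higher or a lower number in this assay stays open among the compounds shown.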